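The compounds below may be only part of what the source reports. "The series", "measured", "known", "first", "only" and "open" are said of these compounds alone.

In a functional assay on G-361 cells (Homo sapiens) for cytotoxicity, read by fluorescence, with a stated time of 72 h (on this read-out higher numbers stand for weaker inhibition and lower numbers for stronger inhibition), three compounds sharing one core differ only in a single substituent: compound 1 `CSc1nc(NCc2ccc(-c3ccccn3)cc2)c2[nH]nc(C(C)C)c2n1` gives 1400 nM, compound 2 `CC(C)c1n[nH]c2c(NCc3ccc(-c4ccccn4)cc3)nc(NCCO)nc12` gives 39 nM, and compound 3 `CC(C)c1n[nH]c2c(NCc3ccc(-c4ccccn4)cc3)nc(NCC(N)CO)nc12` gives 1020 nM. Compound 3 therefore stands within the scatter of compound 1 and far above compound 2, as a 1.4-fold lower number from compound 1 to compound 3 (0.14 log units; within the scatter) and a 26-fold higher number from compound 2 to compound 3 (1.42 log units; beyond the scatter) show. Compound 4 `CC(C)c1n[nH]c2c(NCc3ccc(-c4ccccn4)cc3)nc(N[C@H]3CC[C@H](N)CC3)nc12` carries 4-aminocyclohexyl in place of 2-amino-3-hydroxypropyl on a nitrogen on an aromatic ring. The nearest guide is the large step of a 26-fold higher number from compound 2 to compound 3 (1.42 log units; beyond the scatter), and a 36-fold lower number from compound 1 to compound 2 (1.56 log units; beyond the scatter) is of similar size, so this substituent can clearly shift the number. Going by the values given here, no measured compound carries a ring there, so the size remains uncertain. A substantial fall is expected, with an 8.5-fold lower number from compound 3 to compound 4 (0.93 log units; beyond the scatter) as the estimated step. Compound 4 is estimated at 120 nM, with an expected range of 20 nM to 700 nM.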

Compound 4, half-maximal inhibitory concentration: 745 nM
Estimate against measurement, compound 4: 6.2-fold (0.79 log units) below; measured number outside the range, above it.
By their numbers in this assay, from the lowest: compound 2; then compounds 4, 3 and 1 (each within the scatter of the next).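

In this assay, a ring on this nitrogen reads no differently from the open chain (a 1.4-fold lower number from compound 3 to compound 4 (0.14 log units; within the scatter)), and compound 4 also remains within the scatter of the methylsulfanyl compound (a 1.9-fold lower number from compound 1 to compound 4 (0.27 log units; within the scatter)). The wide gap to the 2-hydroxyethyl compound persists (a 19-fold higher number from compound 2 to compound 4 (1.28 log units; beyond the scatter)), so among these compounds, both amine-bearing substituents stand apart from 2-hydroxyethyl. No available evidence explains this.

The compounds leave open whether the ring or its amine accounts for the gap, and whether 4-hydroxycyclohexyl or a longer hydroxyalkyl chain would read closer to compound 2.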